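The source may report more compounds than this note shows. Statements on the series, on what has been measured and on what is new or still open speak of the compounds shown alone.

Working notes on the series. In an assay on HeLa cells for displacement of a labelled ligand from thyroid hormone receptor alpha (Homo sapiens) (on this read-out higher numbers stand for weaker inhibition and lower numbers for stronger inhibition), compound 1 `CC(C)c1cc(Cn2ccc3cc(OCC(=O)O)cc(Cl)c32)ccc1O` gives 0.35 nM and compound 2 `Cc1cc(OCC(=O)O)cc2cc(C)n(Cc3ccc(O)c(C(C)C)c3)c12` gives 2.05 nM. Compound 2 thus stands at the higher of the two numbers seen in this assay, and the gap to compound 1 lies beyond the scatter. Going by the values given here, the two compounds differ in more than one place, so no single-point step between them can be stated.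

Compound 3 `Cc1cc2cc(OCC(=O)O)cc(Cl)c2n1Cc1ccc(O)c(C(C)C)c1` is compound 2 with one change: chloro in place of methyl on an aromatic carbon. Among the compounds with values here, compound 1 also carries chloro at that place on its core, yet no step between compound 1 and compound 3 is available, since the two differ elsewhere as well.

For compound 3 the expectation is a lower number than compound 2, by a step of a 2.9-fold lower number from compound 2 to compound 3 (0.47 log units; beyond the scatter) in this assay, drawing on the number compound 1 shows at 0.35 nM while allowing that compound 1 is not a single-point neighbour. The estimate for compound 3 in this assay is 0.7 nM, with a range from 0.25 nM to 2 nM.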

Compound 3, inhibition constant: 0.38 nM
The estimate for compound 3 lay 1.8-fold (0.27 log units) above the measured number; measured number inside the range.
By their numbers in this assay, from the lowest: compounds 1 and 3 (each within the scatter of the next); then compound 2.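

In this assay, chloro in place of methyl on an aromatic carbon, ortho to a fused ring and meta to a carboxymethoxy group, gives a 5.4-fold lower number from compound 2 to compound 3 (0.73 log units; beyond the scatter), so this position responds to the change when the core carries its other methyl. Methyl in place of hydrogen on an aromatic carbon gives a 1.1-fold higher number from compound 1 to compound 3 (0.04 log units; within the scatter), so with chloro at the position, that other methyl makes no difference beyond the scatter. Nothing measured here accounts for the size of the chloro step.

Still open, as far as these compounds go, is how hydrogen, fluoro, bromo, trifluoromethyl or a nitrile would stand at the same position. Also open, from the compounds shown here alone, is whether methyl in place of hydrogen would remain within the scatter on a core carrying methyl rather than chloro there.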